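This account rests on a few compounds, and the source may have more. Where it says the series, first, only, none or still open, it means among the compounds named here.

In a functional assay on SK-N-SH cells (Homo sapiens) for cytotoxicity, read by MTT assay, with a stated time of 24 h (a lower number here means a stronger inhibitor, a higher number a weaker inhibitor), compound 1 `O=c1nc2ccc(Br)cn2cc1Cc1ccc(Br)cc1` gives 870 nM and compound 2 `COc1ccc(Cc2cn3cc(Br)ccc3nc2=O)cc1` gives 940 nM, so the two lie within the scatter of each other. Compound 3 `O=c1nc2ccccn2cc1Cc1ccc(Br)cc1` has hydrogen in place of bromo on an aromatic carbon. Among the compounds with values here, the only measured step, a 1.1-fold higher number from compound 1 to compound 2 (0.03 log units; within the scatter), puts methoxy in place of the other bromo, so it bears on this change only indirectly. Within the data shown here, no measured compound alters this bromo. Among the measured compounds shown here, with that small step as the sole guide, the expected change is a 1.3-fold higher number from compound 1 to compound 3 (0.10 log units; within the scatter), with no shift expected beyond the scatter. For compound 3, the estimated value is 1100 nM, with an expected range of 400 nM to 3500 nM.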

Compound 3, half-maximal inhibitory concentration: 163000 nM
Beside the measured number, compound 3's estimate is 150-fold (2.17 log units) below it, and the stated range ends below it.
By their numbers in this assay, from the lowest: compounds 1 and 2 (each within the scatter of the next); then compound 3.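

This carbon of the six-membered aromatic ring with 1 nitrogen turns out to be highly sensitive in this assay: hydrogen in place of its bromo gives a 190-fold higher number from compound 1 to compound 3 (2.27 log units; beyond the scatter). The change at the other bromo, by contrast, gave only a 1.1-fold higher number from compound 1 to compound 2 (0.03 log units; within the scatter), so the two bromo positions of compound 1 do not count equally. No available measurement explains this loss.

Still open, from the compounds shown here alone, is whether bromo itself is needed here, or whether another group, such as chloro, methyl or an amine, would keep the number low. Also open, going by these compounds, is what hydrogen in place of the other bromo would do.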